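A few compounds are considered here, and "the series" means these few. Any claim that something is new, unique, unknown or untested is made for them only; others in the source may bear on it.

Compound 2 `Cc1ccccc1C(=O)Nc1cccc(-c2oc3cc(-c4ccc(F)cc4)ccc3c(=O)c2O)c1` belongs to a set of three compounds that share one core and differ only in the ring joined to the carbonyl carbon of the amide. In a functional assay on HepG2 cells (Homo sapiens) for antiproliferative activity, read by CCK-8 assay, with a stated time of 72 h (on this read-out lower numbers stand for stronger inhibition and higher numbers for weaker inhibition), compound 2 gives 19400 nM, the highest of the three numbers, though none of the three stands apart from the others beyond the scatter. Compound 1 `O=C(Nc1cccc(-c2oc3cc(-c4ccc(F)cc4)ccc3c(=O)c2O)c1)c1ccccc1F` gives 10100 nM in this assay, and compound 3 `Cc1cc(C)cc(C(=O)Nc2cccc(-c3oc4cc(-c5ccc(F)cc5)ccc4c(=O)c3O)c2)c1` gives 13400 nM. The steps among them are all small: a 1.9-fold higher number from compound 1 to compound 2 (0.28 log units; within the scatter), a 1.3-fold higher number from compound 1 to compound 3 (0.12 log units; within the scatter), and a 1.4-fold lower number from compound 2 to compound 3 (0.16 log units; within the scatter).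

Compound 4 `O=C(Nc1cccc(-c2oc3cc(-c4ccc(F)cc4)ccc3c(=O)c2O)c1)c1ccc([N+](=O)[O-])cc1` has not yet been measured in this assay. It differs from compound 2 in one place: 4-nitrophenyl in place of 2-methylphenyl on a carbonyl carbon

Every measured step exchanges one ring at that same carbonyl carbon for another, and each of them stayed within the scatter. For the measured compounds named here, no measured compound carries a 4-nitrophenyl there, so the data give no step of this exact kind, and the expectation rests only on how little the earlier exchanges at this place moved the number. For compound 4 the expected step is therefore a 1.4-fold lower number from compound 2 to compound 4 (0.14 log units; within the scatter), no more than the scatter. Compound 4 is estimated at 14000 nM, with a range from 5000 nM to 40000 nM.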

Compound 4, half-maximal inhibitory concentration: 1860 nM
Beside the measured number, compound 4's estimate is 7.5-fold (0.88 log units) above it, outside the stated range (below it).
By their numbers in this assay, from the lowest: compound 4; then compounds 1, 3 and 2 (each within the scatter of the next).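

The carbonyl carbon of the amide is not a place where ring exchanges always leave the number unchanged: in this assay there is a 10-fold lower number from compound 2 to compound 4 (1.02 log units; beyond the scatter) when 4-nitrophenyl enters, and the same ring gives a 7.2-fold lower number from compound 3 to compound 4 (0.86 log units; beyond the scatter) and a 5.4-fold lower number from compound 1 to compound 4 (0.73 log units; beyond the scatter) as well. The exchanges among 2-fluorophenyl, 2-methylphenyl and 3,5-dimethylphenyl stayed within the scatter, so only the 4-nitrophenyl ring of compound 4 shows that this place can respond strongly to the ring it carries, with compound 4 set apart from each of the other three by a step beyond the scatter. Nothing measured here explains why the number falls so far with this ring.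

For the compounds shown here, compound 4 is the only compound with a nitro group, so these compounds cannot separate the effect of the group itself from that of where it sits on the ring. They also leave open whether a phenyl ring carrying a nitrile, an amine or a carboxylic acid in place of the nitro group would give a similarly low number in this assay on this same core.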